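The source may report more compounds than this note shows. Statements on the series, on what has been measured and on what is new or still open speak of the compounds shown alone.

Among the compounds with values here, compound 3, `C[C@@H](O)CNC(C)(C)C(=O)N[C@@H]1CCc2ccccc2N(Cc2ccc(-c3ccccc3-c3nn[nH]n3)cc2)C1=O`, gives 300 nM in a functional assay (Pituitary gland cell) with Rattus norvegicus as the target (a lower number here means that less compound is needed, a higher number that more compound is needed for the effect), the highest of the three numbers measured so far. Compound 1, `CCOC(=O)CNC(C)(C)CC(=O)N[C@@H]1CCc2ccccc2N(Cc2ccc(-c3ccccc3-c3nn[nH]n3)cc2)C1=O`, gives 56 nM in this assay, and compound 2, `CC(C)(O)CNC(C)(C)CC(=O)N[C@@H]1CCc2ccccc2N(Cc2ccc(-c3ccccc3-c3nn[nH]n3)cc2)C1=O`, gives 10 nM. The steps to compound 3 are both beyond the scatter: a 5.4-fold higher number from compound 1 to compound 3 (0.73 log units; beyond the scatter) and a 30-fold higher number from compound 2 to compound 3 (1.48 log units; beyond the scatter).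

Compound 4, `CC(=O)O[C@@H](C)CNC(C)(C)CC(=O)N[C@@H]1CCc2ccccc2N(Cc2ccc(-c3ccccc3-c3nn[nH]n3)cc2)C1=O`, has not yet been measured. It differs from compound 3 by 2-((2-acetoxypropyl)amino)-2-methylpropyl in place of 1-((2-hydroxypropyl)amino)-1-methylethyl on a carbonyl carbon. The change restores the longer chain seen in compound 1 and compound 2 and at the same time exchanges the free hydroxyl of compound 3 for an acetoxy group. Within the data shown here, two measured steps bear on this. The step of a 30-fold higher number from compound 2 to compound 3 (1.48 log units; beyond the scatter) was large, and the step of a 5.4-fold higher number from compound 1 to compound 3 (0.73 log units; beyond the scatter) was modest; both run towards compound 3 and would be reversed in direction here. Within the longer-chain pair the step of a 5.6-fold lower number from compound 1 to compound 2 (0.75 log units; beyond the scatter) shows the ester-bearing compound 1 standing above the hydroxyl-bearing compound 2, so compound 4, which carries an ester, is expected to land between compound 1 and compound 2 rather than matching compound 2. The expected step is therefore a 7.5-fold lower number from compound 3 to compound 4 (0.88 log units; beyond the scatter), a lower number and beyond the scatter. Compound 4 is estimated at 40 nM, with a range from 10 nM to 150 nM.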

Compound 4, concentration for half-maximal effect: 200 nM
The estimate for compound 4 lay 5.0-fold (0.70 log units) below the measured number; measured number outside the range, above it.
By their numbers in this assay, from the lowest: compound 2; then compound 1; then compounds 4 and 3 (each within the scatter of the next).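

Compound 4 shows that the 2-methylpropyl chain on the carbonyl carbon does not by itself bring the number down in this assay: with 2-((2-acetoxypropyl)amino)-2-methylpropyl in place of 1-((2-hydroxypropyl)amino)-1-methylethyl, the result stays within the scatter (a 1.5-fold lower number from compound 3 to compound 4 (0.18 log units; within the scatter)). On the saturated chain carbon bound to an amine nitrogen, the group matters a great deal, with 1-acetoxyethyl giving up what 1-hydroxy-1-methylethyl held (a 20-fold higher number from compound 2 to compound 4 (1.30 log units; beyond the scatter)) and also standing above ethoxycarbonyl (a 3.6-fold higher number from compound 1 to compound 4 (0.55 log units; beyond the scatter)), so among the three compounds with this chain, the two esters both sit above the tertiary alcohol of compound 2. No measurement here accounts for these differences.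

From the compounds shown here alone, the step to compound 4 changes the chain and its end group together, so their separate shares remain open; a free 2-hydroxypropyl group on the longer chain would divide them. Going by these compounds, whether a carboxylic acid in place of ethoxycarbonyl, or a methyl ether in place of the hydroxyl of compound 2, would stay near compound 2 or move towards the esters also remains open.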